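The compounds below may be only part of what the source reports. "The series", "measured", "known", "first", "only" and "open" are said of these compounds alone.

Going by the values given here, in an ADME assay on S9 fraction from liver (Rattus norvegicus) for metabolic stability, read by LC-MS, using NADPH, with a stated time of 30 min (a higher number here means that more of the compound is left, a lower number that less of the compound is left), compound 2 `CCCCCCCCc1ccc(OCC(=O)Cn2nnc(-c3cccs3)n2)cc1` gives 8% and so holds the lower of the two numbers so far, while compound 1 `CCCCCCCCc1ccc(OCC(=O)Cn2nnc(-c3cccc(C(=O)OC)c3)n2)cc1` gives 19% as the only other measurement. The next structure, compound 3 `CCCCCCCCc1ccc(OCC(=O)Cn2nnc(C(=O)O)n2)cc1`, changes the group on an aromatic carbon of the five-membered aromatic ring with 4 nitrogen: carboxy in place of thiophen-2-yl on an aromatic carbon with carboxy in place of thiophen-2-yl. Among the compounds with values here, one measured step bears on this place: a number 11 percentage points lower from compound 1 to compound 2 (beyond the scatter) is modest, beyond the scatter, and exchanges one ring-bearing group for another. Within the data shown here, no measured compound carries carboxy here, so the direction is uncertain and this step offers only a rough size. Resting on that step of a number 11 percentage points lower from compound 1 to compound 2 (beyond the scatter) as a guide, the expected change is a number 12 percentage points higher from compound 2 to compound 3 (beyond the scatter) as a modest rise in the number. Compound 3 is estimated at 20% with an expected range from 6% to 45% in repeated measurements.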

Compound 3, percent of the compound remaining: 52%
The estimate for compound 3 lay 32 percentage points below the measured number; the measured number lies above the stated range.
By their numbers in this assay, from the lowest: compound 2; then compound 1; then compound 3.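

In this assay, the group on the aromatic carbon between two ring nitrogen atoms proves able to move the number much further than the earlier exchange of one ring-bearing group for another had shown. Carboxy in place of thiophen-2-yl gives a number 44 percentage points higher from compound 2 to compound 3 (beyond the scatter) and carboxy in place of 3-(methoxycarbonyl)phenyl gives a number 33 percentage points higher from compound 1 to compound 3 (beyond the scatter) so among these compounds, the one with no ring at this place stands highest. No measurement shown here accounts for this rise.

From the compounds shown here alone, it remains open whether the higher number depends on the free carboxylic acid itself or would also appear with a primary amide, a methyl ester or a hydroxymethyl group on this carbon. Going by these compounds, it also remains open whether a small ring-free group such as methyl would give a similar number.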